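A few compounds are considered here, and "the series" means these few. Any claim that something is new, unique, unknown or untested is made for them only; others in the source may bear on it.

Measured compounds:
compound 1 `COc1ccccc1/C=C/C(=O)c1ccc(OCC(=O)N[C@H]2CCOC2=O)cc1` — 10100 nM
compound 2 `O=C1OCC[C@@H]1NC(=S)SCCOc1ccccc1[N+](=O)[O-]` — 33400 nM
compound 3 `C=CCc1ccc(OCCSC(=S)N[C@H]2CCOC2=O)c(OC)c1` — > 64000 nM

Three compounds have numbers in a functional assay on DU-145 cells (Homo sapiens) for antiproliferative activity, read by MTT assay, with a stated time of 72 h; a lower number here means a stronger inhibitor, a higher number a weaker inhibitor. Compound 1 gives 10100 nM and stands lowest of the two numbers shown. Compound 2 gives 33400 nM, a higher number than compound 1, and the gap between them lies beyond the scatter. Among the measured compounds shown here, for compound 3 the result is a limit of the assay rather than a number, > 64000 nM; it is the one value that sits at the limit of > 64000 nM in this assay, at which 1 of the 3 values shown sits.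

Compound 4 `O=C(COc1ccc(C(=O)/C=C/c2cccc(Br)c2)cc1)N[C@H]1CCOC1=O` shares the core of compound 1 and differs from it in one place: 3-bromophenyl in place of 2-methoxyphenyl on a double-bonded chain carbon bound to a double-bonded chain carbon. For the measured compounds named here, no step between measured compounds resembles this change, so there is nothing to set its size against. Compound 4 is expected to stay close to compound 1, with a step of a 1.3-fold lower number from compound 1 to compound 4 (0.10 log units; within the scatter) that does not clearly leave the scatter. The estimate for compound 4 in this assay is 8000 nM, within a range from 2500 nM to 30000 nM.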

Compound 4, half-maximal inhibitory concentration: 9800 nM
Compound 4: middle estimate off by 1.2-fold (0.09 log units), on the low side; the range from low to high includes it.
By their numbers in this assay, from the lowest: compounds 4 and 1 (each within the scatter of the next); then compound 2. At a limit, above all of these: compound 3.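

In this assay, 3-bromophenyl in place of 2-methoxyphenyl on a double-bonded chain carbon bound to a double-bonded chain carbon gives a 1.0-fold lower number from compound 1 to compound 4 (0.01 log units; within the scatter). This is the only step shown that can be read at this position, and it shows that one aromatic ring can replace the other here, with the methoxy oxygen leaving and a bromine entering, without a change beyond the scatter. No measurement shown bears on why the number holds.

Going by these compounds, whether an amine or a carboxylic acid at this place would also stay within the scatter remains open. Also open, on these data alone, is whether the same exchange would behave alike on the chains of compound 2 and compound 3, which differ from compound 1 in more than one place.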